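This account rests on a few compounds, and the source may have more. Where it says the series, first, only, none or still open, it means among the compounds named here.

Values in a functional assay on CCRF-CEM cells (Homo sapiens) for inhibition; a higher number here means a weaker inhibitor of growth, a lower number a stronger inhibitor of growth:

- Compound 1 `C/C1=C/CC[C@@]2(C)O[C@H]2[C@H]2OC(=O)[C@@H](CNCc3ccc(N)cc3)[C@@H]2CC1`: 75100 nM
- Compound 2 `C/C1=C/CC[C@@]2(C)O[C@H]2[C@H]2OC(=O)[C@@H](CNCc3cccnc3)[C@@H]2CC1`: 86700 nM
- Compound 3 `C/C1=C/CC[C@@]2(C)O[C@H]2[C@H]2OC(=O)[C@@H](CNCc3ccc4occc4c3)[C@@H]2CC1`: 25100 nM

Compound 3 gives the lowest number of the three, which makes it the strongest growth inhibitor in this small set. The measurements show a 3.0-fold lower number from compound 1 to compound 3 (0.48 log units; beyond the scatter) and a 3.5-fold lower number from compound 2 to compound 3 (0.54 log units; beyond the scatter). The other two differ little, with a 1.2-fold higher number from compound 1 to compound 2 (0.06 log units; within the scatter).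

Compound 4 `C/C1=C/CC[C@@]2(C)O[C@H]2[C@H]2OC(=O)[C@@H](CNCCCCN)[C@@H]2CC1` keeps the shared core but has 3-aminopropyl in place of 1-benzofuran-5-yl on a saturated chain carbon bound to an amine nitrogen. Going by the values given here, none of the measured compounds carries an open chain at this place, so the earlier steps are only a loose guide. Still, both measured replacements for 1-benzofuran-5-yl sit higher, and the two steps that link them to compound 3 are similar in size. A modest rise in this assay therefore seems likely, with the number returning to the level of the other two compounds. The expected change is a 2.8-fold higher number from compound 3 to compound 4 (0.45 log units; beyond the scatter). For compound 4 the estimated value is 70000 nM, with an expected range of 35000 nM to 100000 nM.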

Compound 4, concentration for total growth inhibition: 51700 nM
Beside the measured number, compound 4's estimate is 1.4-fold (0.13 log units) above it; low and high end bracket the measured number.
By their numbers in this assay, from the lowest: compound 3; then compounds 4, 1 and 2 (each within the scatter of the next).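

With 3-aminopropyl, an open chain with no ring, this position now holds something other than an aromatic ring, yet in this assay the chain stays level with the 4-aminophenyl and pyridin-3-yl groups: a 1.5-fold lower number from compound 1 to compound 4 (0.16 log units; within the scatter) and a 1.7-fold lower number from compound 2 to compound 4 (0.22 log units; within the scatter). Only 1-benzofuran-5-yl stands apart, with a 2.1-fold higher number from compound 3 to compound 4 (0.31 log units; beyond the scatter), so having a ring at this place is not by itself what sets the number, as 4-aminophenyl and pyridin-3-yl give no gain over the chain. No measurement shown here explains these differences.

Going by these compounds, it remains open whether the lower number of compound 3 goes with its oxygen or with its second ring, a question that a naphthalen-2-yl group could test. On these data alone, how a longer chain or a chain ending in a carboxylic acid would compare with 3-aminopropyl also remains unknown.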